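The source may hold more compounds than are shown below. What is called first, only, known or untested is meant among the compounds shown, and "the series" means these compounds.

Compound 1 `C=C1C(=O)O[C@@H]2C/C(C)=C/CC/C(C)=C/CC[C@]3(C)O[C@H]3C[C@@H]12` is a macrocyclic lactone with a fused epoxide. In a functional assay on A549 cells (Homo sapiens) for cytotoxicity (a higher number here means that more compound is needed for the effect, a lower number that less compound is needed), compound 1 gives 8.31 ug/mL, the higher of the two values recorded so far. Its companion, compound 2 `C=C1C(=O)O[C@@H]2[C@H]1[C@H](OC(C)=O)C/C(C)=C/C[C@H](OC(C)=O)/C(C)=C/C[C@@H](OC(C)=O)[C@]1(C)O[C@@H]21`, which carries three acetoxy groups on the same kind of core, gives 4.29 ug/mL in this assay; the two values lie within the scatter of each other, so no order between compounds 1 and 2 can be claimed.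

Compound 3 `C=C1C(=O)O[C@H]2[C@H]1C[C@@H]1O[C@@]1(C)CC/C=C(\C)CC/C=C(\C)[C@@H]2OC(C)=O` has not yet been measured. It differs from compound 1 by acetoxy in place of hydrogen on a saturated ring carbon. Going by the values given here, no directly comparable step between measured compounds exists, so the expectation rests only on the two values above, which suggest that adding acetoxy does not move the number beyond the scatter. The step of a 1.3-fold lower number from compound 1 to compound 3 (0.11 log units; within the scatter) is therefore expected to be small, if any, and slightly downward. Compound 3 is estimated at 6.5 ug/mL in this assay, within a range from 3 ug/mL to 14 ug/mL.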

Compound 3, concentration for half-maximal effect: 4.66 ug/mL
For compound 3 the middle estimate is 1.4-fold (0.14 log units) above the measured one; the range from low to high includes it.
By their numbers in this assay, from the lowest: compounds 2, 3 and 1 (each within the scatter of the next).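

In this assay the step of a 1.8-fold lower number from compound 1 to compound 3 (0.25 log units; within the scatter) comes with acetoxy in place of hydrogen on a saturated ring carbon of the 14-membered ring, next to the ring atom that bears a methyl group. Going by these compounds alone, this is the first comparison of compounds that differ in one place, and it lies within the scatter, so at this position acetoxy and hydrogen cannot be told apart in this measurement. Nothing available explains this result or bears on it.

On these data alone, whether a hydroxyl group, an amine or a longer acyl chain at this same carbon would give a step beyond the scatter remains open. The compounds shown also leave open what a single acetoxy group does at any other carbon of the shared core.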